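The source may report more compounds than this note shows. Statements on the series, on what has been measured and on what is new or still open speak of the compounds shown alone.

Measured compounds:
Compound 1 `CSc1c(C#N)c(N)c(C#N)c(-c2ccccc2)c1-c1ccccc1` — in an assay on isolated protein for inhibition of Maltase-glucoamylase (Homo sapiens), tested at 100 uM (a lower number here means less inhibition, a higher number more inhibition at the concentration tested (going by the name of the read-out)), compound 1 gives 10.5%.
Compound 2 `COc1ccc(-c2c(C#N)c(N)c(C#N)c(SC)c2-c2ccccc2)cc1` — compound 2 gives 5.7%.
Compound 3 `CSc1c(C#N)c(N)c(C#N)c(C)c1-c1ccc(C(F)(F)F)cc1` — compound 3 gives 22.1%.

Compound 2 stands lowest of the three numbers, but its gap to compound 1 is within the scatter, so the two cannot be ordered. Only compound 3 lies beyond the scatter above it. Going by the values given here, the one step recorded, a number 4.8 percentage points lower from compound 1 to compound 2 (within the scatter), concerns the methoxy group and not the change at hand.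

Compound 4 `COc1ccc(-c2c(C)c(SC)c(C#N)c(N)c2C#N)cc1` differs from compound 2 by methyl in place of phenyl on an aromatic carbon. Among the compounds with values here, no measured step isolates this change. Within the data shown here, compound 3 also carries a methyl where compound 1 and compound 2 carry a phenyl, yet it differs in the trifluoromethyl group too, so its values show only that the methyl-bearing compound 3 sits higher than compound 2, without saying why.

Leaning on that single comparison, he expects a small rise at best, with the step of a number 6.3 percentage points higher from compound 2 to compound 4 (within the scatter) likely staying within the scatter. His estimate for compound 4 is 12%, within a range from 0% to 28%.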

Compound 4, a percentage reported as inhibition, at one concentration (the size of the read-out at that concentration, not a potency): 17.3%
For compound 4 the middle estimate is 5.3 percentage points below the measured one, within the range that was stated.
By their numbers in this assay, from the lowest: compounds 2, 1, 4 and 3 (each within the scatter of the next, the first and the last beyond it).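

In this assay, going by these compounds alone, putting methyl in place of phenyl on the aromatic carbon para to an amino group gives a number 11.6 percentage points higher from compound 2 to compound 4 (beyond the scatter), the first step that isolates this position from any other change. The phenyl group at this carbon is therefore not needed for the low level of inhibition seen at the tested concentration, since compound 4 with methyl there gives 17.3% and so reads beyond the scatter above compound 2. No measurement on hand accounts for this step.

Within the data shown here, only this one pair isolates the change, so it stays open whether the same swap would raise the read-out on a core that lacks the 4-methoxyphenyl group. Also open, going by these compounds, is how an amine, a carboxylic acid or a longer chain such as propyl would read on this carbon in place of the methyl.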